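Methoxy for methyl on the aryl ring of compound 1

A few compounds are considered here, and "the series" means these few. Any claim that something is new, unique, unknown or untested is made for them only; others in the source may bear on it.

Measured so far in a functional assay on MCF7 cells (Homo sapiens), tested at 7.5 uM; on this read-out lower numbers stand for a stronger effect and higher numbers for a weaker effect at the one concentration tested:
compound 1, `CC(C)=CCOc1c(C)c(C)c2c(c1C)CCC(C)(COc1ccc(/C=C3\SC(=O)NC3=O)cc1C)O2`, gives 27% in this assay;
compound 2, `Cc1c(C)c2c(c(C)c1OCc1ccccc1)CCC(C)(COc1ccc(/C=C3\SC(=O)NC3=O)cc1)O2`, gives 12% in this assay;
compound 3, `C=CCOc1c(C)c(C)c2c(c1C)CCC(C)(COc1cccc(/C=C3\SC(=O)NC3=O)c1)O2`, gives 75% in this assay.

Compound 1 stands second highest of the three numbers. Compound 2 lies lower, beyond the scatter, and compound 3 lies higher, also beyond the scatter.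

Compound 4, `COc1cc(/C=C2\SC(=O)NC2=O)ccc1OCC1(C)CCc2c(C)c(OCC=C(C)C)c(C)c(C)c2O1`, is not yet measured. It differs from compound 1 in one place: methoxy in place of methyl on an aromatic carbon. Among the compounds with values here, no measured pair shows this change, so nothing fixes its size. A small step is expected, in either direction, most likely none beyond the scatter. Compound 4 is therefore expected to give about 30%, in the range 15% to 55%. The expected step of a number 3 percentage points higher from compound 1 to compound 4 (within the scatter) is small.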

Compound 4, a percentage reported as activity, at one concentration (the size of the read-out at that concentration, not a potency): 54%
Beside the measured number, compound 4's estimate is 24 percentage points below it; the measured number falls inside the stated range.
By their numbers in this assay, from the lowest: compound 2; then compound 1; then compound 4; then compound 3.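

In this assay methoxy in place of methyl on this aromatic carbon, ortho to a large group, gives a number 27 percentage points higher from compound 1 to compound 4 (beyond the scatter) and so a weaker effect at the one concentration tested. Within the data shown here, this is the first one-place change read, and it shows that this position does not tolerate the swap without a loss beyond the scatter. Nothing at hand accounts for the step.
Still open, on these data alone, is whether a hydroxyl, a chlorine or an ethoxy on the same carbon would keep or lose the effect of compound 1.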